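Trifluoromethyl in Place of Fluoro at the Para Position

The compounds below may be only part of what the source reports. "The series", "measured", "known", "first", "only" and "open" are said of these compounds alone.

Compound 3 `CC(C)n1nc2c(c1-c1ccc(F)cc1)CCNCC2` carries a fluoro group para to a large group on the six-membered aromatic ring of carbon only. In an ADME assay on membranes from Cortex for displacement of a labelled ligand from Adrenergic receptor alpha-1 (Rattus norvegicus), read by radioligand binding, with a stated time of 60 min (a higher number here means a weaker inhibitor, a lower number a stronger inhibitor), compound 3 gives 170 nM, the second highest of the three numbers measured. Compound 1 `c1ccc(-c2c3c(nn2C2CCC2)CCNCC3)cc1` gives 500 nM, and compound 2 `CC(C)n1nc2c(c1-c1ccc(Cl)cc1)CCNCC2` gives 20 nM. Within the data shown here, the only step that bears on the change is an 8.5-fold higher number from compound 2 to compound 3 (0.93 log units; beyond the scatter). Compound 4 `CC(C)n1nc2c(c1-c1ccc(C(F)(F)F)cc1)CCNCC2` makes the change (trifluoromethyl in place of fluoro on an aromatic carbon). Since the swap from chloro to fluoro raised the number, replacing fluoro is expected to lower it again, toward the value of compound 2, which is 20 nM. For compound 4 the estimate is 40 nM, in the range 10 nM to 160 nM, a step expected to be a 4.3-fold lower number from compound 3 to compound 4 (0.63 log units; beyond the scatter).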

Compound 4, inhibition constant: 130 nM
Compound 4: middle estimate off by 3.3-fold (0.51 log units), on the low side, within the range that was stated.
By their numbers in this assay, from the lowest: compound 2; then compounds 4 and 3 (each within the scatter of the next); then compound 1.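

In this assay trifluoromethyl in place of fluoro gives a 1.3-fold lower number from compound 3 to compound 4 (0.12 log units; within the scatter) and so no readable change at this position. Trifluoromethyl in place of chloro gives a 6.5-fold higher number from compound 2 to compound 4 (0.81 log units; beyond the scatter) and fluoro in place of chloro gives an 8.5-fold higher number from compound 2 to compound 3 (0.93 log units; beyond the scatter) so of these three groups chloro alone stands clearly apart, with the lowest number. Nothing measured here offers a reason for this pattern.

From the compounds shown here alone, what an amine, a carboxylic acid or a methoxy group would give at this same aromatic carbon remains open.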